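Benzyl to ethyl on the ring nitrogen of the shared core

This account rests on a few compounds, and the source may have more. Where it says the series, first, only, none or still open, it means among the compounds named here.

Measured in an ADME assay on BaF3 cells (Mus musculus) for inhibition, read by CellTiter-Glo, with a stated time of 72 h; a lower number here means a stronger inhibitor of growth, a higher number a weaker inhibitor of growth:
- Compound 1 `Cc1ccc(Nc2ncc3c(n2)N(c2ccccc2)C(=O)N(c2cc(NC(=O)c4ccc(C)c(C(F)(F)F)c4)ccc2C)C3)cn1`: 3300 nM
- Compound 2 `Cc1ccc(Nc2ncc3c(n2)N(Cc2ccccc2)C(=O)N(c2cc(NC(=O)c4ccc(C)c(C(F)(F)F)c4)ccc2C)C3)cn1`: > 5000 nM

Compound 2 gives > 5000 nM, which is a limit of this assay and not a number. The same position appears in the evidence as the limit of > 5000 nM in this assay, at which 1 of the 2 values shown sits.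

The next analogue is compound 3 `CCN1C(=O)N(c2cc(NC(=O)c3ccc(C)c(C(F)(F)F)c3)ccc2C)Cc2cnc(Nc3ccc(C)nc3)nc21`. Its difference from compound 2 is methyl in place of phenyl on a saturated chain carbon bound to an amide-type nitrogen in a ring. Cut one bond further out, the same change reads benzyl to ethyl.

For the measured compounds named here, only one measured step bears on this change: an at least 1.5-fold higher number from compound 1 to compound 2 (0.18 log units; that floor lies within the scatter). Going by the values given here, that step concerns the same nitrogen, but it gives only a floor, and no measured compound carries ethyl there. It therefore sets neither a firm size nor a firm direction. Among the compounds with values here, compound 1, at 3300 nM, is the only true number nearby, so the expectation is anchored on it. A modest move to a lower number is expected, and a result at the limit remains possible.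

The expected step is an at least 1.6-fold lower number from compound 2 to compound 3 (0.22 log units; that floor lies within the scatter).

For compound 3 the estimated value is 3000 nM, with an expected range of 1000 nM to 7000 nM.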

Compound 3, concentration for 50% growth inhibition: 708 nM
For compound 3 the middle estimate is 4.2-fold (0.63 log units) above the measured one, and the stated range ends above it.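

In this assay, ethyl on the amide-type nitrogen in a ring gives a clear step against phenyl: a 4.7-fold lower number from compound 1 to compound 3 (0.67 log units; beyond the scatter). This makes compound 3 the strongest inhibitor of growth among the three compounds and shows that the group on this nitrogen can shift the number beyond the scatter, which the floor between phenyl and benzyl could not show. Against benzyl, the change reads an at least 7.0-fold lower number from compound 2 to compound 3 (0.84 log units; beyond the scatter), but this is only a floor, and compound 2 stands at a limit of this assay, not at a number: the limit of > 5000 nM in this assay, at which 1 of the 3 values shown sits.

Ethyl is the only saturated chain on this nitrogen among the compounds shown, so one value gives no trend with chain length, and methyl, propyl or a longer chain could fall on either side of compound 3. Also open, on these data alone, are how a chain ending in an amine or a carboxylic acid would read at this nitrogen, and whether the gain from ethyl in place of phenyl would hold with other groups elsewhere on the shared core.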